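Series notes: aryl substituent change on the shared core

The compounds below may be only part of what the source reports. "The series", "measured", "known", "first", "only" and "open" are said of these compounds alone.

Compound 1 `CC(C)C[C@H](N)c1cc(C(F)(F)F)ccc1N1CCN(C(=O)C(C)Cc2ccc(Cl)cc2)CC1` gives 47 nM in an assay on HEK293 cells for displacement of a labelled ligand from Melanocortin receptor 4 (Homo sapiens); a higher number here means a weaker inhibitor, a lower number a stronger inhibitor. Compound 2 `CC(C)C[C@H](N)c1cc(C(F)(F)F)ccc1N1CCN(C(=O)CCNC2CCCCC2)CC1` gives 4800 nM in this assay, and compound 3 `CC(C)C[C@H](N)c1cc(F)ccc1N1CCN(C(=O)C(C)Cc2ccc(Cl)cc2)CC1` gives 390 nM. Among the three numbers compound 3 stands second highest; its nearest neighbour is compound 1, its furthest compound 2. Two steps are known. On the carbonyl carbon, a 100-fold higher number from compound 1 to compound 2 (2.01 log units; beyond the scatter). On the aromatic carbon of the core, an 8.3-fold higher number from compound 1 to compound 3 (0.92 log units; beyond the scatter).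

Compound 4 `CC(C)C[C@H](N)c1cc(Cl)ccc1N1CCN(C(=O)C(C)Cc2ccc(Cl)cc2)CC1` is not yet measured in this assay. Against compound 3 the difference is chloro in place of fluoro on an aromatic carbon, on the same aromatic carbon at which the step from compound 1 to compound 3 was taken. For the measured compounds named here, only that step bears on the present one, and it was modest; the step from compound 1 to compound 2 concerns another part of the molecule and is not informative here. Nothing measured shows chloro at this carbon, so the expectation rests on chloro being an exchange of one heavy atom for another on that carbon, between the fluoro of compound 3 and the trifluoromethyl of compound 1. A step toward a lower number is therefore expected, of size a 2.6-fold lower number from compound 3 to compound 4 (0.41 log units; beyond the scatter), probably beyond the scatter but smaller than the step from compound 1 to compound 3. For compound 4 the estimate in this assay is 150 nM, with a range from 60 nM to 400 nM.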

Compound 4, inhibition constant: 67 nM
Compound 4: middle estimate off by 2.2-fold (0.35 log units), on the high side; the range from low to high includes it.
By their numbers in this assay, from the lowest: compounds 1 and 4 (each within the scatter of the next); then compound 3; then compound 2.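

For the compounds shown here, at the aromatic carbon para to a large group, in this assay, the earlier compounds showed only that fluoro and trifluoromethyl differ; the change from fluoro to chloro now gives a 5.8-fold lower number from compound 3 to compound 4 (0.76 log units; beyond the scatter) and so shows that a change of a single halogen is enough to produce a step beyond the scatter. Trifluoromethyl is also not needed for the lower number at this carbon, since chloro in place of trifluoromethyl gives a 1.4-fold higher number from compound 1 to compound 4 (0.15 log units; within the scatter) and leaves the two groups indistinguishable in this read-out, with fluoro the only one of the three substituents set apart from the others. Nothing available explains why fluoro stands apart from chloro and trifluoromethyl at this carbon.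

Going by these compounds, whether bromo, methoxy or a nitrile at the same carbon would group with chloro and trifluoromethyl or with fluoro remains open. Also open, on these data alone, is whether the difference between fluoro and chloro carries over when 2-(cyclohexylamino)ethyl stands on the carbonyl carbon in place of 1-(4-chlorobenzyl)ethyl.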